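This account rests on a few compounds, and the source may have more. Where it says the series, first, only, none or still open, it means among the compounds named here.

Two related compounds have so far been measured in a functional assay on HeLa cells (Homo sapiens) for inhibition, read by MTT assay, with a stated time of 48 h; a higher number here means a weaker inhibitor, a lower number a stronger inhibitor. Compound 1 `COc1ccc(C(c2c[nH]c3ccc(Br)cc23)c2c[nH]c3ccc(Br)cc23)cc1OC` carries a 3,4-dimethoxyphenyl group on a saturated chain carbon bound to two aromatic carbons, and in this assay compound 1 gives 6100 nM. Compound 2 `Brc1ccc2[nH]cc(C(c3ccc4ccccc4c3)c3c[nH]c4ccc(Br)cc34)c2c1` carries a naphthalen-2-yl group in that place, and in this assay compound 2 gives 4300 nM. Of these two numbers, compound 1 stands highest, its nearest neighbour being compound 2, with a 1.4-fold lower number from compound 1 to compound 2 (0.15 log units; within the scatter).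

Compound 3 `O=[N+]([O-])c1ccc(C(c2c[nH]c3ccc(Br)cc23)c2c[nH]c3ccc(Br)cc23)cc1` has not yet been measured. It differs from compound 1 in one place: 4-nitrophenyl in place of 3,4-dimethoxyphenyl on a saturated chain carbon bound to two aromatic carbons. For the measured compounds named here, the only measured step that bears on this change is the exchange of the group in the same place, a 1.4-fold lower number from compound 1 to compound 2 (0.15 log units; within the scatter). That one exchange moved the number only within the scatter, so a single measured step gives no direction to lean on, and no step beyond the scatter is expected here either. Compound 3 is therefore expected near 5000 nM, within a range from 2000 nM to 12000 nM. The step this estimate implies is expected to be a 1.2-fold lower number from compound 1 to compound 3 (0.09 log units; within the scatter).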

Compound 3, half-maximal inhibitory concentration: 1500 nM
Compound 3: the middle estimate sits 3.3-fold (0.52 log units) above what was measured; measured number outside the range, below it.
By their numbers in this assay, from the lowest: compound 3; then compounds 2 and 1 (each within the scatter of the next).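

The earlier pair left open whether this position, on a saturated chain carbon bound to two aromatic carbons, responds to a change of group at all. 4-Nitrophenyl in place of 3,4-dimethoxyphenyl now gives a 4.1-fold lower number from compound 1 to compound 3 (0.61 log units; beyond the scatter) and, in place of naphthalen-2-yl, a 2.9-fold lower number from compound 2 to compound 3 (0.46 log units; beyond the scatter) so the group here does matter in this assay and compound 3 is the strongest inhibitor of the three. The gain does not follow the hydrogen-bond acceptor count, which is the same for 3,4-dimethoxyphenyl and 4-nitrophenyl, and nothing measured here explains why this group lowers the number.

For the compounds shown here, with only three groups compared, it remains open whether the lower number belongs to the nitro group itself or would also appear with other groups, such as 4-aminophenyl, 4-carboxyphenyl or 3-nitrophenyl, in the same place. These compounds also leave open how far the number could fall at this position, and whether an unsubstituted phenyl would sit nearer to compound 3 or to compound 1.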